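The source may hold more compounds than are shown below. What is called first, only, known or untested is meant among the compounds shown, and "the series" means these compounds.

Of the compounds shown here, three that share one core have been read in an ADME assay on H9 cells (Homo sapiens) for cytotoxicity, read by XTT assay, with a stated time of 6 days; on this read-out lower numbers stand for higher toxicity in this test and higher numbers for lower toxicity in this test. Compound 1 (`Cc1cccc(C)c1Oc1ccc([N+](=O)[O-])c(Nc2ccc(C#N)cc2)c1`), which has only a hydrogen at the position of interest, gives 69600 nM. Compound 2 (`Cc1cc(C#N)cc(C)c1Oc1ccc([N+](=O)[O-])c(Nc2ccc(C#N)cc2)c1`), with a cyano group there, gives > 65100 nM, which is a limit of the assay and not a number. Compound 3 (`Cc1cc(C=O)cc(C)c1Oc1ccc([N+](=O)[O-])c(Nc2ccc(C#N)cc2)c1`), with a formyl group there, gives 14200 nM, the lower of the two actual numbers.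

The next step exchanges that formyl for bromo and leads to compound 4 (`Cc1cc(Br)cc(C)c1Oc1ccc([N+](=O)[O-])c(Nc2ccc(C#N)cc2)c1`): bromo in place of formyl on an aromatic carbon. The change sits on an aromatic carbon, meta to two methyl groups.

Among the measured compounds shown here, two measured steps bear on it. Placing formyl where hydrogen stood gave a 4.9-fold lower number from compound 1 to compound 3 (0.69 log units; beyond the scatter). Placing formyl where cyano stood gave an at least 4.5-fold lower number from compound 2 to compound 3 (0.66 log units; beyond the scatter). Among these three compounds, then, only the one carrying formyl has a clearly lower number. For the measured compounds named here, no measured compound carries bromo, so its own effect remains open, and a partial return upward seems the most reasonable expectation. The expected change is a 2.5-fold higher number from compound 3 to compound 4 (0.39 log units; beyond the scatter), a modest rise in this assay with wide uncertainty. Compound 4 is estimated at 35000 nM, with an expected range from 12000 nM to 90000 nM.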

Compound 4, half-maximal cytotoxic concentration: > 57000 nM
Compound 4 was reported as a limit; the forecaster's own chance of this, stated with the estimate: 30%; middle value at least 1.6-fold (0.21 log units) away from the limit.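

With formyl and bromo on the same aromatic carbon, this assay gives an at least 4.0-fold higher number from compound 3 to compound 4 (0.60 log units; beyond the scatter), so the lower number seen with formyl does not carry over to bromo at this place. Compound 4 is reported only as a limit of the assay and not as a number: the limit of > 57000 nM in this assay, at which 1 of the 4 values shown sits. Across the four compounds, the steps printed for compound 3 against each of the others all lie beyond the scatter, so within this small set the clearly lower number appears only with formyl, and hydrogen, cyano and bromo do not show it.

The steps from compound 1 and from compound 2 to compound 4 cannot be read, so hydrogen, cyano and bromo cannot be placed in order against one another in this test. It also remains open whether the lower number is special to formyl or would return with a carboxylic acid, an amide or an amine on this same carbon, since none of these groups appears among the compounds shown.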